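The source may hold more compounds than are shown below. What is called first, only, known or untested is meant among the compounds shown, and "the series" means these compounds.

Compound 1 `CCn1c(-c2ccccc2)nc2c(NC3CCCCC3)ncnc21`: 707 nM
Compound 2 `Cn1c(-c2ccccc2)nc2c(NC3CCCCC3)ncnc21`: 2370 nM
Compound 3 `CCn1c(-c2ccccc2)nc2c(NC3CCC3)ncnc21`: 84 nM

All three were tested in an assay on CHO cells for displacement of a labelled ligand from adenosine receptor A3 (Homo sapiens), read by scintillation counting, with a stated time of 3 h; a higher number here means a weaker inhibitor, a lower number a stronger inhibitor. Compound 3 stands lowest of the three numbers. Among the measured compounds shown here, the nearest of the others is compound 1, and the step of an 8.4-fold lower number from compound 1 to compound 3 (0.93 log units; beyond the scatter) is the only change on the ring-bound nitrogen among the measured pairs. Compound 2 is furthest from compound 3; its value in this assay lies above that of compound 1 as well.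

The next compound, compound 4 `CCCn1c(-c2ccccc2)nc2c(NC3CCC3)ncnc21`, keeps the cyclobutyl group of compound 3 and differs only on the chain attached to the aromatic nitrogen: methyl in place of hydrogen on a saturated chain carbon, two bonds along the chain from an aromatic nitrogen. Cut one bond further out, this reads as ethyl to propyl.

For the measured compounds named here, one measured step bears on it. Shortening the same chain gave a 3.4-fold higher number from compound 1 to compound 2 (0.53 log units; beyond the scatter), a modest rise, so adding length in the opposite direction has so far gone with a lower number. Whether a further extension continues that trend cannot be read from a single step, so the expectation is a small decrease or no change beyond the scatter. Compound 4 is therefore expected near 55 nM, with a range of 20 nM to 150 nM, the estimated step being a 1.5-fold lower number from compound 3 to compound 4 (0.18 log units; within the scatter).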

Compound 4, inhibition constant: 264 nM
The estimate for compound 4 lay 4.8-fold (0.68 log units) below the measured number; the measured number lies above the stated range.
By their numbers in this assay, from the lowest: compound 3; then compound 4; then compound 1; then compound 2.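

Lengthening the chain on the aromatic nitrogen from ethyl to propyl does not continue the earlier direction: in this assay, the added methyl gives a 3.1-fold higher number from compound 3 to compound 4 (0.50 log units; beyond the scatter) on the compounds that carry cyclobutyl. Among the compounds shown, a longer chain therefore does not always mean a lower number, since ethyl beats methyl with cyclohexyl on the ring-bound nitrogen, while ethyl beats propyl with cyclobutyl there. The effect of one methyl at the end of this chain thus depends on the compound that receives it, and the two steps point in opposite directions by more than the scatter allows: the same change on two cores in this assay, a 3.4-fold higher number (0.53 log units; beyond the scatter) from compound 1 to compound 2 and a 3.1-fold lower number (0.50 log units; beyond the scatter) from compound 4 to compound 3, 11-fold (1.02 log units) apart, beyond the scatter of two such steps.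

These two steps differ both in the ring on the nitrogen and in the chain length at which the methyl is added, so the compounds shown cannot say which of the two sets the direction. A butyl or isopropyl chain on the aromatic nitrogen of the cyclobutyl series, or a cyclopentyl group on the ring-bound nitrogen, remains an open case.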